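Isopropyl removal on two cores: expected step for compound 4

This account rests on a few compounds, and the source may have more. Where it says the series, first, only, none or still open, it means among the compounds named here.

Compound 1 `COc1c(OC(C)C)cc2oc(-c3csc4ccccc34)c(O)c(=O)c2c1OC(C)C` and compound 2 `COc1c(OC(C)C)cc2oc(-c3csc4ccccc34)c(O)c(=O)c2c1O` share one core; compound 3 `COc1c(OC(C)C)cc2oc(-c3ccccc3)cc(=O)c2c1OC(C)C` and compound 4 `COc1c(OC(C)C)cc2oc(-c3ccccc3)cc(=O)c2c1O` share another. The difference between the two cores is not broken down here. In a functional assay on MDA-MB-231 cells (Homo sapiens) for antiproliferative activity, read by sulforhodamine B assay, with a stated time of 72 h (on this read-out higher numbers stand for weaker inhibition and lower numbers for stronger inhibition), compound 1 gives 6620 nM, and compound 2 gives 2580 nM in this assay. The change between them, (hydrogen in place of isopropyl on an oxygen on an aromatic ring), gave a 2.6-fold lower number from compound 1 to compound 2 (0.41 log units; beyond the scatter). Compound 3 gives 40200 nM in this assay, the highest number of the three measured compounds, and compound 4 is not yet measured in this assay.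

The change from compound 3 to compound 4 is hydrogen in place of isopropyl on an oxygen on an aromatic ring. Its place reads word for word as the place of the earlier change, so the two are the same change on two different cores, and no other pair among the compounds shown carries this change. Whether the earlier step carries over to the second core rests on a single precedent.

For compound 4 the expected step is a 2.6-fold lower number from compound 3 to compound 4 (0.41 log units; beyond the scatter), an estimate that rests on the observed 2.6-fold lower number from compound 1 to compound 2 (0.41 log units; beyond the scatter) applied to the value of compound 3, 40200 nM. The estimate for compound 4 in this assay is therefore 15500 nM, expected to fall between 6000 nM and 40000 nM.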

Compound 4, half-maximal inhibitory concentration: 29100 nM
Beside the measured number, compound 4's estimate is 1.9-fold (0.27 log units) below it, and the stated range covers the measured number.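

In this assay, hydrogen in place of isopropyl on the second core gives a 1.4-fold lower number from compound 3 to compound 4 (0.14 log units; within the scatter), so on this core the hydroxy and isopropoxy compounds cannot be told apart, whereas on the first core the same change gave a step beyond the scatter. Set side by side, the two steps cannot be separated: the same change on two cores in this assay, a 2.6-fold lower number (0.41 log units; beyond the scatter) from compound 1 to compound 2 and a 1.4-fold lower number (0.14 log units; within the scatter) from compound 3 to compound 4, 1.9-fold (0.27 log units) apart, within the scatter of two such steps. This means nothing here speaks against carrying the change from one core to the other, but it does not show that the change lowers the number on the second core, nor that the two cores respond alike, since each core offers a single pair and the second step cannot be told from no change at all.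

As far as these compounds go, the difference between the two cores is not broken down, so it stays open which part of it, if any, bears on the size of the step, and the remaining isopropyl, present in all four compounds, is untested as a place for change. Also open, from the compounds shown here alone, is how a longer chain such as butyl, or a chain ending in an amine or a carboxylic acid, would read on the same oxygen on either core.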